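Removing the Side Arm of Compound 3

The source may report more compounds than this note shows. Statements on the series, on what has been measured and on what is new or still open speak of the compounds shown alone.

Of the compounds shown here, three built on one shared core have been tested in a functional assay on HCT-116 cells (Homo sapiens) for antiproliferative activity, read by MTT assay, with a stated time of 72 h; a higher number here means a weaker inhibitor, a lower number a stronger inhibitor. Compound 1, `Cc1ccc(-c2cn(C/C=C3\OC(=O)C(OCc4ccccc4)=C3OCc3ccccc3)nn2)cc1`, reaches only the limit of this assay with > 100000 nM. Compound 2, `CCCCCc1ccc(-c2cn(C/C=C3\OC(=O)C(OCc4ccccc4)=C3OCc3ccccc3)nn2)cc1`, likewise sits at the limit with > 100000 nM. Among the measured compounds shown here, the one change between them, a step that the two limits leave unreadable from compound 1 to compound 2, cannot be read because of the limit of > 100000 nM in this assay, at which 2 of the 3 values shown sit. Compound 3, `O=C1O[C@H]([C@@H](O)Cn2cc(CNS(=O)(=O)c3ccc(F)cc3)nn2)C(OCc2ccccc2)=C1OCc1ccccc1`, is the only one to give a real number, 22900 nM, and so stands as the sole readable point among the three.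

Compound 4, `O=C1O[C@H]([C@@H](O)Cn2ccnn2)C(OCc2ccccc2)=C1OCc1ccccc1`, keeps the core of compound 3 but differs in one place: hydrogen in place of (((4-fluorophenyl)sulfonyl)amino)methyl on an aromatic carbon. For the measured compounds named here, no measured step covers a change of this kind; the one step that was measured concerns a different position and is itself unreadable. Going by the values given here, with the arm gone, compound 4 is a smaller molecule than compound 3, and the expectation can rest on nothing beyond that and the single number of compound 3. The estimate for compound 4 is therefore 60000 nM, with a range from 15000 nM to 150000 nM. This means an expected step of a 2.6-fold higher number from compound 3 to compound 4 (0.42 log units; beyond the scatter), a weakening that may well leave compound 4 at the limit of this assay rather than at a number.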

Compound 4, half-maximal inhibitory concentration: > 100000 nM
Compound 4 gave a limit, no number; the forecaster's own chance of this, stated with the estimate: 50%; at least 1.6-fold (0.22 log units) between middle value and limit.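

The earlier compounds shown here offered no readable step, since their two limits leave the change between them unreadable, but this pair gives one: in this assay, replacing the (((4-fluorophenyl)sulfonyl)amino)methyl arm on the aromatic carbon of the five-membered ring with hydrogen gives an at least 4.3-fold higher number from compound 3 to compound 4 (0.64 log units; beyond the scatter). That size is only a lower bound, because compound 4 gave a limit and not a number: the limit of > 100000 nM in this assay, at which 3 of the 4 values shown sit. Among the compounds shown, this carbon is therefore the first position where a change has a readable effect, and the only real number in the set is lost once the arm is gone.

Removing the arm takes away the fluorinated aromatic ring, the sulfonyl group, the nitrogen and the methylene link all at once, so the compounds shown do not tell which of these parts matters. As far as these compounds go, it also stays open whether a smaller group on the same carbon, such as aminomethyl, or an arm ending in a plain phenyl ring or a carboxylic acid, would keep a real number in this assay.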